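The source may hold more compounds than are shown below. What is called first, only, known or untested is meant among the compounds shown, and "the series" means these compounds.

Measured compounds:
- compound 1 `O=[N+]([O-])c1cc(OCc2ccccc2)ccc1CNc1cc(C(F)(F)F)cc2[nH]ncc12`: > 100000 nM
- compound 2 `O=[N+]([O-])c1ccccc1CNc1cccc2[nH]ncc12`: "nd" (no result reported)

The read-out throughout is an assay for inhibition of Indoleamine 2,3-dioxygenase 1 (Homo sapiens), with stated times of 10 min and 60 min; on this read-out lower numbers stand for stronger inhibition and higher numbers for weaker inhibition. For compound 1 the value is a limit of the assay, not a number: in this assay compound 1 gives > 100000 nM. For compound 2 no number is reported in this assay, the entry being "nd" (no result reported). Compound 2 therefore stands nowhere on the numbers shown; the only value in the set sits at the limit of > 100000 nM in this assay, at which 1 of the 2 values shown sits, and no step between measured compounds can be read from it.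

Compound 3 `COC(=O)c1cc(NCc2ccccc2[N+](=O)[O-])c2cn[nH]c2c1` follows from compound 2 by methoxycarbonyl in place of hydrogen on an aromatic carbon. Within the data shown here, with compound 2 unmeasured, no step in this assay can be sized for this change, in either direction, from the data. Among the measured compounds shown here, the one value sits at the limit of > 100000 nM in this assay, at which 1 of the 2 values shown sits, so weak inhibition is the baseline expectation. Compound 3 is estimated to fall at 60000 nM, within 5000 nM to 200000 nM, with a substantial chance that this assay again reports only a limit.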

Compound 3, half-maximal inhibitory concentration: > 100000 nM
Compound 3 ended at the assay's limit (the forecaster's own chance of this, stated with the estimate: 55%); middle value at least 1.6-fold (0.22 log units) away from the limit.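

No step can be read between compound 2 and compound 3, since only compound 3 carries a value: in this assay compound 3 gives > 100000 nM, a limit and not a number. The compounds shown leave open whether methoxycarbonyl in place of hydrogen changes inhibition at all, and what substitution on the shared core would bring inhibition within the measurable range.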